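Dropping One Chlorine from a Poorly Soluble Acid

The source may report more compounds than this note shows. Statements on the series, on what has been measured and on what is new or still open speak of the compounds shown alone.

Compound 1 `O=C(O)COc1c(Cl)cc([C@H]2CC[C@]3(CC2)OOC2(O3)C3CC4CC(C3)CC2C4)cc1Cl` joins a carboxymethoxy group and two chloro groups on an aromatic ring to the shared core. In a physicochemical assay for solubility, read by nephelometry, in phosphate buffer, measured as kinetic solubility, with a stated time of 30 min, at pH 6.5 (on this read-out higher numbers stand for higher solubility and lower numbers for lower solubility), compound 1 gives < 3.1 ug/mL, which is a limit of the assay rather than a number, and it is one of the values that sit at the limit described by the limit of < 3.1 ug/mL in this assay, at which 1 of the 3 values shown sits. Compound 2 `O=C(O)CNC(=O)COc1ccc([C@H]2CC[C@]3(CC2)OOC2(O3)C3CC4CC(C3)CC2C4)cc1` gives 12.5 ug/mL in this assay. Compound 3 `CC(C)(Oc1ccc([C@H]2CC[C@]3(CC2)OOC2(O3)C3CC4CC(C3)CC2C4)cc1)C(=O)O` gives < 1.6 ug/mL in this assay, again a limit, the one described by the limit of < 1.6 ug/mL in this assay, at which 1 of the 3 values shown sits. For the measured compounds named here, the single measured step, an at least 7.8-fold lower number from compound 2 to compound 3 (0.89 log units; beyond the scatter), changes the acid-bearing group on the oxygen and leaves the aromatic ring untouched, so it does not speak directly to a change at a ring position.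

Compound 4 `O=C(O)COc1ccc([C@H]2CC[C@]3(CC2)OOC2(O3)C3CC4CC(C3)CC2C4)cc1Cl` differs from compound 1 by hydrogen in place of chloro on an aromatic carbon. Going by the values given here, no measured step covers the loss of a chloro group, so the expectation rests on the small size of the change and on the low starting point of compound 1. Compound 4 is expected to give about 5 ug/mL in this assay, within a range from 1.6 ug/mL to 15 ug/mL. The expected step of an at least 1.6-fold higher number from compound 1 to compound 4 (0.20 log units; that floor lies within the scatter) is modest and may again end at a limit of the assay.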

Compound 4, solubility: < 3.1 ug/mL
Compound 4: no number, only a limit (the forecaster's own chance of this, stated with the estimate: 40%); at least 1.6-fold (0.20 log units) between middle value and limit.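

In this assay compound 4 gives < 3.1 ug/mL, a limit of the assay and not a number. Compound 1 also stands at a limit, so the change from compound 1 to compound 4 cannot be read. The compounds shown leave open whether hydrogen in place of chloro on the aromatic carbon changes solubility at all, and by how much.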